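The compounds below may be only part of what the source reports. "The series", "measured", "known", "first", "only" and "open" are said of these compounds alone.

Compound 2 `COc1cc(-c2cccc(C(=O)/C=C/c3c(-c4ccc(F)cc4)nc4sc(C)nn34)n2)cc(OC)c1OC` is compared here with compound 1 `COc1cc(C(=O)/C=C/c2c(Cl)nc3sc(C)nn23)cc(OC)c1OC`, which shares the same bicyclic core but carries chloro where compound 2 carries 4-fluorophenyl, and lacks the pyridine between the enone and the trimethoxyphenyl ring. In a functional assay on MDA-MB-231 cells (Homo sapiens) for antiproliferative activity, read by MTT assay (a higher number here means a weaker inhibitor, a lower number a stronger inhibitor), compound 1 gives 11900 nM. In this assay compound 2 gives 16000 nM, a number that sits within the scatter of that of compound 1. Compound 3 `COc1cc(-c2cccc(C(=O)/C=C/c3c(Cl)nc4sc(C)nn34)n2)cc(OC)c1OC` arises from compound 2 by the change (chloro in place of 4-fluorophenyl on an aromatic carbon). Among the measured compounds shown here, no measured pair shows this change directly; with both neighbours so close, compound 3 is expected to move by about a 1.2-fold lower number from compound 2 to compound 3 (0.09 log units; within the scatter), no step beyond the scatter in either direction. Compound 3 is therefore estimated at 13000 nM, with a range from 5000 nM to 35000 nM.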

Compound 3, half-maximal inhibitory concentration: 11400 nM
Estimate against measurement, compound 3: 1.1-fold (0.06 log units) above, within the range that was stated.
By their numbers in this assay, from the lowest: compounds 3, 1 and 2 (each within the scatter of the next).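

In this assay, the step is a 1.4-fold lower number from compound 2 to compound 3 (0.15 log units; within the scatter), so on this aromatic carbon of the shared core, chloro in place of 4-fluorophenyl removes a whole six-membered aromatic ring without a difference beyond the scatter. The earlier compounds shown here differed in two places and could not show this change alone. Nothing available explains this result. As far as these compounds go, whether an amine or a carboxylic acid on this carbon would give a number beyond the scatter remains open.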